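An Aminobenzyl Group in Place of Cyclohexyl

This account rests on a few compounds, and the source may have more. Where it says the series, first, only, none or still open, it means among the compounds named here.

Compound 1 `c1ccc(Cn2nnc3c(NC4CCCCC4)ncnc32)cc1` carries a cyclohexyl group on a nitrogen attached to its aromatic core. In an assay on cell membranes for binding affinity to adenosine receptor A1 (Bos taurus), read by radioligand binding (on this read-out lower numbers stand for stronger inhibition and higher numbers for weaker inhibition), compound 1 gives 121 nM. Among the values shown, this is the only one that is an actual number. Compound 2 `Nc1ccc(Nc2ncnc3c2nnn3Cc2ccccc2Cl)cc1` is reported in this assay only as a limit, > 1000 nM. Compound 3 `O=[N+]([O-])c1ccc(CNc2ncnc3c2nnn3Cc2ccccc2Cl)cc1` likewise reaches only a limit, > 1000 nM. So the limit of > 1000 nM in this assay, at which 2 of the 3 values shown sit, is where most of the shown values sit, and compound 1 stands clearly apart from that limit.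

Compound 4 `Nc1ccc(CNc2ncnc3c2nnn3Cc2ccccc2)cc1` has not yet been measured. It differs from compound 1 in one place: 4-aminobenzyl in place of cyclohexyl on a nitrogen on an aromatic ring. Compound 2 and compound 3 also place substituted aromatic groups on that nitrogen, yet each differs from compound 1 in more than one place, so neither offers a direct step from it.

Going by the values given here, no step between measured compounds is available here. Given that compound 2 and compound 3 both sit at the limit of > 1000 nM in this assay, at which 2 of the 3 values shown sit, the expectation is a loss of affinity well beyond the usual scatter from compound 1 to compound 4, a 12-fold higher number from compound 1 to compound 4 (1.09 log units; beyond the scatter). Compound 4 is therefore estimated at 1500 nM, with a range from 300 nM to 8000 nM, and this assay may well report only a limit for it.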

Compound 4, inhibition constant: 9500 nM
Estimate against measurement, compound 4: 6.3-fold (0.80 log units) below; the measured number lies above the stated range.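

Going by these compounds alone, this is the first direct reading at this position: with the rest of the molecule unchanged, 4-aminobenzyl in place of cyclohexyl on a nitrogen on an aromatic ring gives a 79-fold higher number from compound 1 to compound 4 (1.89 log units; beyond the scatter) in this assay. So this nitrogen does not accept any ring equally, and replacing the non-aromatic carbon ring with this aromatic group costs a large part of the binding affinity seen for compound 1. Compound 2 and compound 3 could only hint at this, since each differs from compound 1 in more than one place, whereas compound 4 gives a true number that sets the size of the loss, and the weak end of the set now has a measured point alongside the limits: the limit of > 1000 nM in this assay, at which 2 of the 4 values shown sit.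

The entering group brings both an aromatic ring and an amine, and this single step cannot separate the two, so a plain benzyl group on the same nitrogen would be the telling comparison. Also open, from the compounds shown here alone, is how much of the cyclohexyl ring is needed, which a cyclopentyl group or a short alkyl chain at this position would begin to answer.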